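Nitro to methyl: cytotoxicity working notes

This account rests on a few compounds, and the source may have more. Where it says the series, first, only, none or still open, it means among the compounds named here.

In an ADME assay on MT4 cells (Homo sapiens) for cytotoxicity, read by MTT assay, with a stated time of 96 h (on this read-out higher numbers stand for lower toxicity in this test and lower numbers for higher toxicity in this test), compound 1 (`Cc1ccc(/N=N/c2ccc(NCCCN(C)C)cc2)cc1`) gives 17000 nM and compound 2 (`CN(C)CCCN(/N=N/c1ccc([N+](=O)[O-])cc1)c1ccccc1`) gives 20000 nM on the same read-out. Within the data shown here, these two values lie within the scatter of each other, so compound 2 stands level with the only other measured compound. Compound 3 (`Cc1ccc(/N=N/N(CCCN(C)C)c2ccccc2)cc1`) follows from compound 2 with methyl in place of nitro on an aromatic carbon and is otherwise unchanged. Among the measured compounds shown here, no measured step isolates this change. Compound 2 carries nitro and compound 1 carries methyl, but that pair also differs elsewhere, and compound 1 gives 17000 nM in this comparison. On that limited evidence, no step beyond the scatter is expected in this assay for this change. The estimated step is a 1.1-fold lower number from compound 2 to compound 3 (0.05 log units; within the scatter) and nothing larger is expected. For compound 3 the expected value is 18000 nM within an estimated range from 8000 nM to 40000 nM on this read-out.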

Compound 3, half-maximal cytotoxic concentration: 18000 nM
Compound 3: middle estimate and measured number agree at the digits printed; the measured number falls inside the stated range.
By their numbers in this assay, from the lowest: compounds 1, 3 and 2 (each within the scatter of the next).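

In this assay, among these compounds, methyl in place of nitro on an aromatic carbon, para to a large group, gives a 1.1-fold lower number from compound 2 to compound 3 (0.05 log units; within the scatter) as the first measured step that isolates this change. At this position, then, 3 heavy atoms with 2 hydrogen-bond acceptors give way to 1 heavy atom with 0 hydrogen-bond acceptors, and the number stays level, which the pair of compound 1 and compound 2 could not show, as those two also differ elsewhere. No measurement on hand bears on why this exchange leaves the read-out level.

On these data alone, whether an amine or a carboxylic acid at this same position would also stay within the scatter remains open. Equally open, as far as these compounds go, is whether a longer chain in place of the shared side chain would move the number, or whether methyl in place of nitro would give a similar step on another core.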